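From Nitro to Amino on an Aryl Guanidine

A few compounds are considered here, and "the series" means these few. Any claim that something is new, unique, unknown or untested is made for them only; others in the source may bear on it.

Compound 2, `Cc1ccccc1/N=C(/N)Nc1ccc([N+](=O)[O-])cc1C`, was measured in an assay on membranes from brain (Cavia porcellus) for binding affinity to Sigma non-opioid intracellular receptor 1 (Homo sapiens) (on this read-out higher numbers stand for weaker inhibition and lower numbers for stronger inhibition), and gives 39 nM. Of the two numbers recorded so far it stands highest. Among the measured compounds shown here, the only other measured compound, compound 1, `Cc1ccccc1/N=C(\N)NC1CCCCC1`, gives 15 nM in this assay, a lower number, and the gap between compound 1 and compound 2 lies beyond the usual scatter of repeated measurements. For the measured compounds named here, the two compounds differ in more than one place, so no step that isolates a single change has been observed, and nothing about the effect of any one change is yet known.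

Compound 3, `Cc1ccccc1/N=C(/N)Nc1ccc(N)cc1C`, has not been measured in this assay. Its difference from compound 2 is amino in place of nitro on an aromatic carbon. With no comparable change shown among the measured compounds, the expectation rests on compound 2 alone and carries a wide range. The step that this estimate means, a 1.5-fold higher number from compound 2 to compound 3 (0.19 log units; within the scatter), is expected to be small and toward a higher number, possibly within the scatter. Compound 3 is therefore estimated at 60 nM in this assay, with a range from 15 nM to 250 nM.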

Compound 3, half-maximal inhibitory concentration: 220 nM
Compound 3: the middle estimate sits 3.7-fold (0.56 log units) below what was measured, within the range that was stated.
By their numbers in this assay, from the lowest: compound 1; then compound 2; then compound 3.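

Among the compounds shown here, this is the first step in this assay that isolates a single change, and it shows that the aromatic carbon meta to a methyl group and para to a large group is sensitive to what it carries: amino in place of nitro gives a 5.6-fold higher number from compound 2 to compound 3 (0.75 log units; beyond the scatter). The exchange replaces three heavy atoms with one, and two hydrogen-bond acceptors and no donor with one of each, so on this shared core the nitro compound holds the lower number of the pair. No measurement is available that would tie the step to any one of these differences or to any property of the two groups.

The compounds shown leave open whether the step comes from removing nitro or from introducing amino, and whether a nitrile, a methoxy group or a plain hydrogen on the same aromatic carbon would fall nearer compound 2 or compound 3. They also leave open whether the exchange would act the same way on another core, as compound 1 differs from compound 2 in more than one place and offers no second instance.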